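The compounds below may be only part of what the source reports. "The series", "measured", "known", "first", "only" and "open" are said of these compounds alone.

In an ADME assay on a cell-free system (plasma, Rattus norvegicus, strain Sprague-Dawley) for metabolic stability, read by LC-MS, with a stated time of 120 min, tested at 1 uM (on this read-out lower numbers stand for a less stable compound and higher numbers for a more stable compound), compound 1 (`CC#CCn1c(N2CCC[C@@H](N)C2)nc2c1c(=O)n(Cc1ccc(Br)cc1C(=O)OC)c(=O)n2C`) gives 54.2% and compound 2 (`CC#CCn1c(N2CCC[C@@H](N)C2)nc2c1c(=O)n(Cc1ccc(Cl)cc1C(=O)OCc1oc(=O)oc1C)c(=O)n2C`) gives 1.25% as the lower of the two numbers, beyond the scatter. These two differ in more than one place, so no single step can be read between them. Compound 3 (`CC#CCn1c(N2CCC[C@@H](N)C2)nc2c1c(=O)n(Cc1ccc(Cl)cc1C(=O)O)c(=O)n2C`) follows from compound 2 by one change (a hydrogen atom in place of a group of 8 heavy atoms (5 carbon, 3 oxygen; one five-membered aromatic ring with 2 hetero atoms), on an oxygen next to a carbonyl group), which puts a hydrogen atom on an oxygen next to a carbonyl group. Compound 2 at 1.25% leaves almost the whole scale open upward. A large rise beyond the scatter is expected (a number 90.8 percentage points higher from compound 2 to compound 3 (beyond the scatter)) in this read-out. Compound 3 is estimated at 92% within an expected range of 75% to 108% on repeated measurement.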

Compound 3, percent of the compound remaining: 102%
Compound 3: the middle estimate sits 10 percentage points below what was measured; measured number inside the range.
By their numbers in this assay, from the lowest: compound 2; then compound 1; then compound 3.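

In this assay, replacing the group of 8 heavy atoms on the oxygen next to a carbonyl group with a hydrogen atom gives a number 100.8 percentage points higher from compound 2 to compound 3 (beyond the scatter), showing how much this one place can move the read-out. The exchange of 4-bromo-2-(methoxycarbonyl)phenyl for 2-carboxy-4-chlorophenyl gives a number 47.8 percentage points higher from compound 1 to compound 3 (beyond the scatter), but it changes the halogen and the oxygen substituent together, so their shares cannot be separated. Nothing measured here bears on the cause of either step. The compounds shown leave open how an ethyl group or a longer alkyl chain on that oxygen would read. They also leave open how a methyl group on that oxygen would read with chlorine in place of bromine.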